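Purine glycinamide benzyl esters in the oral tail flick test

A few compounds are considered here, and "the series" means these few. Any claim that something is new, unique, unknown or untested is made for them only; others in the source may bear on it.

Compound 1 `C[C@H](NC(=O)CN(c1nc(Cl)nc2[nH]cnc12)C1CC1)C(=O)OCc1ccccc1` carries a methyl group that compound 2 `O=C(CN(c1nc(Cl)nc2[nH]cnc12)C1CC1)NCC(=O)OCc1ccccc1` lacks; the change is hydrogen in place of methyl on a saturated chain carbon bound to an amide-type nitrogen and a carbonyl carbon. In a functional assay on the whole organism (Tail, strain ICR) with Mus musculus as the target, in the tail flick test, with a stated time of 90 min, at a dose of 25 umol/kg by the oral route (on this read-out higher numbers stand for a stronger effect at the one dose given and lower numbers for a weaker effect), compound 1 gives 44.2%, and compound 2 gives 27.2%, a step of a number 17 percentage points lower from compound 1 to compound 2 (beyond the scatter). Compound 3 `C[C@@H](O)[C@H](NC(=O)CN(c1ncnc2c1ncn2C1CCCCO1)C1CC1)C(=O)OCc1ccccc1` rests on a different core; the difference between the two cores is not broken down here. In this assay compound 3 gives 23.4%. Compound 4 `O=C(CN(c1ncnc2c1ncn2C1CCCCO1)C1CC1)N[C@@H](CO)C(=O)OCc1ccccc1` relates to compound 3 by hydrogen in place of methyl on a saturated chain carbon bound to an oxygen on a saturated carbon and a saturated chain carbon. This is the same kind of change, not the same: there the carbon was bound to an amide-type nitrogen and a carbonyl carbon, here it is bound to an oxygen on a saturated carbon and a saturated chain carbon. From compound 3 to compound 4 a step of a number 9.4 percentage points lower from compound 3 to compound 4 (within the scatter) is expected, resting on the earlier drop of a number 17 percentage points lower from compound 1 to compound 2 (beyond the scatter), with only part of that size carried over given the differing place. The estimate for compound 4 is 14%.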

Compound 4, a percentage reported as activity, at one dose (the size of the read-out at that dose, not a potency): 32.2%
Compound 4: the middle estimate sits 18.2 percentage points below what was measured, and the stated range ends below it.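

In this assay hydrogen in place of methyl gives a number 8.8 percentage points higher from compound 3 to compound 4 (within the scatter) and so does not separate the two compounds. Set beside the earlier step, the change does not carry from the core of compound 1 to the core of compound 3 with one size or direction: the same change on two cores in this assay, a number 17 percentage points lower (beyond the scatter) from compound 1 to compound 2 and a number 8.8 percentage points higher (within the scatter) from compound 3 to compound 4, 25.8 percentage points apart, beyond the scatter of two such steps. This rests on a single pair per core, with the change at a different place in each pair, so core and place cannot be told apart as the source of the gap.

Open, going by these compounds, is how a free carboxylic acid in place of the benzyl ester would read on either core. Also open, on these data alone, is whether a longer chain in place of hydroxymethyl would shift the read-out.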